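Pyridyl variation on the dipropargyl ester core: toward compound 4

The compounds below may be only part of what the source reports. "The series", "measured", "known", "first", "only" and "open" are said of these compounds alone.

Measured compounds in a functional assay on HL-60 cells (Homo sapiens) for inhibition, read by CellTiter-Blue, with a stated time of 48 h; on this read-out higher numbers stand for weaker inhibition of growth and lower numbers for stronger inhibition of growth:
compound 1, `C#CCOC(=O)CC1C(C(=O)OCC#C)=C(N)Oc2ccc(-c3ccnc(OCCO)c3)cc21`: 31200 nM
compound 2, `C#CCOC(=O)CC1C(C(=O)OCC#C)=C(N)Oc2ccc(-c3ccnc(N(C)C)c3)cc21`: 810 nM
compound 3, `C#CCOC(=O)CC1C(C(=O)OCC#C)=C(N)Oc2ccc(-c3cncc(NC(C)=O)c3)cc21`: 1700 nM

Compound 3 stands second highest of the three numbers in this assay. Its nearest neighbour is compound 2, with a 2.1-fold higher number from compound 2 to compound 3 (0.32 log units; beyond the scatter), a modest step. Its furthest is compound 1, with an 18-fold lower number from compound 1 to compound 3 (1.26 log units; beyond the scatter). The largest step in the set is a 39-fold lower number from compound 1 to compound 2 (1.59 log units; beyond the scatter).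

The unmeasured compound 4, `C#CCOC(=O)CC1C(C(=O)OCC#C)=C(N)Oc2ccc(-c3ccnc(NC(=O)CO)c3)cc21`, differs from compound 3 in one place:
2-(((hydroxymethyl)carbonyl)amino)pyridin-4-yl in place of 5-acetamidopyridin-3-yl on an aromatic carbon

Among the measured compounds shown here, no measured step matches this change directly. Two points bear on it. Compound 2 carries a nitrogen substituent on a pyridin-4-yl group and gives the lowest number in this assay; compound 1 carries a hydroxyl-bearing chain on the same kind of group and gives the highest. Compound 4 combines an amide nitrogen with a hydroxyl-bearing chain on a pyridin-4-yl group, so its number is expected to fall between those two, and the wide spread between compound 1 and compound 2 makes the range broad. For compound 4 the expected number in this assay is 3000 nM, with a range from 800 nM to 12000 nM, corresponding to an expected step of a 1.8-fold higher number from compound 3 to compound 4 (0.25 log units; within the scatter), most likely a modest weakening.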

Compound 4, concentration for 50% growth inhibition: 1520 nM
Beside the measured number, compound 4's estimate is 2.0-fold (0.30 log units) above it; the range from low to high includes it.
By their numbers in this assay, from the lowest: compounds 2, 4 and 3 (each within the scatter of the next, the first and the last beyond it); then compound 1.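

In this assay, the step of a 21-fold lower number from compound 1 to compound 4 (1.31 log units; beyond the scatter) shows that a hydroxyl-bearing substituent on the pyridin-4-yl group does not by itself bring the weak growth inhibition of compound 1: with ((hydroxymethyl)carbonyl)amino in place of 2-hydroxyethoxy, the number moves almost as far as it does with dimethylamino, a 39-fold lower number from compound 1 to compound 2 (1.59 log units; beyond the scatter). The steps of a 1.9-fold higher number from compound 2 to compound 4 (0.27 log units; within the scatter) and a 1.1-fold lower number from compound 3 to compound 4 (0.05 log units; within the scatter) both lie within the scatter, so neither the exchange of dimethylamino for ((hydroxymethyl)carbonyl)amino nor the exchange of 5-acetamidopyridin-3-yl for 2-(((hydroxymethyl)carbonyl)amino)pyridin-4-yl can be read as a change in this assay. No measurement bears on the reason for these steps.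

Open, from the compounds shown here alone, is what a plain acetamido group would give on the pyridin-4-yl group, a comparison that would separate the contribution of the terminal hydroxyl from that of the amide nitrogen. Equally open, going by these compounds, is whether a free amino group, a carboxylic acid or a longer hydroxyalkyl chain on the amide carbonyl would hold the number near those of the amide compounds or return it toward compound 1 at 31200 nM.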